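The source may hold more compounds than are shown below. What is called first, only, known or untested is meant among the compounds shown, and "the series" means these compounds.

Measured so far in a functional assay on MDA-MB-231 cells (Homo sapiens) for inhibition, read by sulforhodamine B assay, with a stated time of 74 h; on this read-out higher numbers stand for weaker inhibition and lower numbers for stronger inhibition:
- compound 1 `O=C1C=CC2(C=C1)OCC(=O)N2S(=O)(=O)c1ccc(Cl)cc1`: 2800 nM
- compound 2 `O=C1C=CC2(C=C1)OCC(=O)N2S(=O)(=O)c1ccc([N+](=O)[O-])cc1`: > 10000 nM (a limit)
- compound 3 `O=C1C=CC2(C=C1)OCC(=O)N2S(=O)(=O)c1ccc(N2CCCC2=O)cc1`: > 10000 nM (a limit)

Compound 3 has no number, only a limit, and stands at the limit of > 10000 nM in this assay, at which 2 of the 3 values shown sit. The next analogue, compound 4 `O=C1C=CC2(C=C1)OCC(=O)N2S(=O)(=O)c1ccc(OC(F)(F)F)cc1`, carries trifluoromethoxy in place of 2-oxopyrrolidin-1-yl on an aromatic carbon. Within the data shown here, no trifluoromethoxy analogue has been measured, so the evidence is indirect. The measured steps at this place are an at least 3.5-fold higher number from compound 1 to compound 2 (0.55 log units; beyond the scatter) and an at least 3.5-fold higher number from compound 1 to compound 3 (0.55 log units; beyond the scatter), each starting from chloro. The remaining step, a step that the two limits leave unreadable from compound 2 to compound 3, gives no size. Among the measured compounds shown here, the expectation therefore rests on compound 1 at 2800 nM, the only number. A return towards that value is expected, though a further limit remains a real possibility. The expected change in this assay is an at least 2.8-fold lower number from compound 3 to compound 4 (0.45 log units; beyond the scatter), towards stronger inhibition. Compound 4 is estimated at 3500 nM, with an expected range of 1200 nM to 10000 nM.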

Compound 4, half-maximal inhibitory concentration: > 10000 nM
Compound 4 ended at the assay's limit (the forecaster's own chance of this, stated with the estimate: 30%); middle value at least 2.8-fold (0.45 log units) from the limit.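

In this assay trifluoromethoxy is now the third group on this aromatic carbon, after nitro and 2-oxopyrrolidin-1-yl, to end at the limit of the assay: the limit of > 10000 nM in this assay, at which 3 of the 4 values shown sit.
Among these compounds, replacing chloro with trifluoromethoxy gives an at least 3.5-fold higher number from compound 1 to compound 4 (0.55 log units; beyond the scatter) and leaves chloro as the only group with a number.
The steps from compound 2 and from compound 3 to compound 4 cannot be read, with limits at both ends, so nitro, 2-oxopyrrolidin-1-yl and trifluoromethoxy cannot be ranked against one another.

On these data alone, it remains open whether chloro is alone in giving a number at this position, or whether bromo, methyl or a dimethylamino group would also do so.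
As far as these compounds go, how far compound 2, compound 3 and compound 4 lie past the limit also remains unknown.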